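Branched alkyl on the ring nitrogen of a fused core

The source may hold more compounds than are shown below. What is called first, only, known or untested is meant among the compounds shown, and "the series" means these compounds.

Measured compounds:
compound 1 `CC[C@@H](C1CC1)n1c(=O)c(C)nc2c(-c3ccc(Cl)cc3Cl)nccc21`: 55 nM
compound 2 `CCCC(C1CC1)n1c(=O)c(C)nc2c(-c3ccc(Cl)cc3Cl)ccnc21`: 4.3 nM

In a functional assay for antagonist activity at corticotropin-releasing factor receptor 1 (Rattus norvegicus) (on this read-out higher numbers stand for weaker inhibition and lower numbers for stronger inhibition), compound 2 gives 4.3 nM, the lower of the two numbers recorded so far, while compound 1 gives 55 nM. Compound 1 and compound 2 do not differ in one place only, so the two values are shown side by side without a single step being drawn between them.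

Compound 3 `Cc1nc2c(-c3ccc(Cl)cc3Cl)ccnc2n(C(C)C(C)C)c1=O` has not yet been measured. It differs from compound 2 in one place: 1,2-dimethylpropyl in place of 1-cyclopropylbutyl on an aromatic nitrogen. Among the compounds with values here, no pair of measured compounds shows this exchange, so the size of its effect on this assay is unknown. Compound 3 is expected to sit somewhat weaker than compound 2, with the step from a 2.3-fold higher number from compound 2 to compound 3 (0.37 log units; beyond the scatter) estimated as modest and possibly within the scatter. For compound 3 the estimate is 10 nM, with a range from 3 nM to 40 nM.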

Compound 3, half-maximal inhibitory concentration: 380 nM
Compound 3: middle estimate off by 38-fold (1.58 log units), on the low side; the whole stated range lies below it.
By their numbers in this assay, from the lowest: compound 2; then compound 1; then compound 3.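

Within the data shown here, this is the first step at this position between compounds that differ in one place only, and in this assay the exchange of 1-cyclopropylbutyl for 1,2-dimethylpropyl on the aromatic nitrogen brings an 88-fold higher number from compound 2 to compound 3 (1.95 log units; beyond the scatter) as a large loss of inhibition. The position therefore does not accept these two branched alkyl groups alike, even though neither group carries a hydrogen-bond donor, a hydrogen-bond acceptor or a net charge. The change is confined to carbon: the entering group has fewer heavy atoms and no three-membered ring.

This single step cannot tell whether the loss of the ring or the shorter chain accounts for the difference, and a 1-propylbutyl group on the same core would keep the chain without the ring. Nothing shown here gives a reason for the size of this step.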